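The compounds below may be only part of what the source reports. "The series", "measured", "known", "first", "only" and "open" are said of these compounds alone.

In an assay on cells for agonist activity at probable G-protein coupled receptor 34 (Mus musculus), with a stated time of 1 h (on this read-out lower numbers stand for smaller maximal responses and higher numbers for larger maximal responses), compound 1 `Cc1ccccc1Oc1cccc(COc2ccccc2CCC(=O)OCCCOP(=O)(O)OC[C@H](N)C(=O)O)c1` gives 20.3%, compound 2 `Cc1cccc(Oc2cccc(COc3ccccc3CCC(=O)OCCCOP(=O)(O)OC[C@H](N)C(=O)O)c2)c1` gives 21.3%, and compound 3 `N[C@@H](COP(=O)(O)OCCCOC(=O)CCc1ccccc1OCc1cccc(Oc2ccc(Cl)cc2)c1)C(=O)O` gives 17.8%. Compound 3 sits alongside the other two: the steps of a number 2.5 percentage points lower from compound 1 to compound 3 (within the scatter) and a number 3.5 percentage points lower from compound 2 to compound 3 (within the scatter) both fall within the scatter, as does a number 1 percentage points higher from compound 1 to compound 2 (within the scatter). Compound 4 `N[C@@H](COP(=O)(O)OCCCOC(=O)CCc1ccccc1OCc1cccc(Oc2ccc(F)cc2)c1)C(=O)O` differs from compound 3 in one place: fluoro in place of chloro on an aromatic carbon. Each measured step exchanges the ring carried on the oxygen, and since none of them moved this assay beyond the scatter, swapping one halogen for another at the same spot is expected to leave the maximal response near that of compound 3, with an expected step of a number 0.7 percentage points higher from compound 3 to compound 4 (within the scatter). Compound 4 is therefore estimated at 18.5%, within a range of 10% to 28%.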

Compound 4, largest response reached (Emax), in percent of the reference or control that the assay uses: 18.7%
Compound 4: middle estimate off by 0.2 percentage points, on the low side, within the range that was stated.
By their numbers in this assay, from the lowest: compounds 3, 4, 1 and 2 (each within the scatter of the next).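

Earlier steps exchanged the whole ring on the oxygen, whereas this one changes only the halogen para to a large group, giving a number 0.9 percentage points higher from compound 3 to compound 4 (within the scatter) in this assay and leaving fluoro and chloro indistinguishable there. The 4-fluorophenyl group also stays level with both methylphenyl groups, with a number 2.6 percentage points lower from compound 2 to compound 4 (within the scatter) and a number 1.6 percentage points lower from compound 1 to compound 4 (within the scatter) in this assay. Nothing available explains this flat result. On these data alone, whether an amine, a carboxylic acid or a longer chain at this place would shift the maximal response remains open.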